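The compounds below may be only part of what the source reports. "The series", "measured", "known", "first", "only" and "open" are said of these compounds alone.

Compound 1, `CC(C)N(Cc1cccc(OCCCCCC(=O)O)c1)C(=O)c1ccc(-c2cccc(-c3ccccc3)c2)cc1`, heads a small set of carboxylic acid amides examined for cytotoxicity. In an ADME assay on Raji cells (Homo sapiens) for cytotoxicity, read by CellTiter-Glo and resazurin assay, with a stated time of 72 h (on this read-out lower numbers stand for an effect already at smaller amounts and higher numbers for an effect only at larger amounts of compound), compound 1 gives > 26000 nM, which is a limit of the assay and not a number. Compound 2, `CC(C)N(Cc1cccc(OCCCCCC(=O)O)c1)C(=O)c1ccc(-c2ccco2)cc1`, carries furan-2-yl in place of 3-phenylphenyl on an aromatic carbon. In this assay compound 2 gives > 26000 nM, again a limit. Compound 3, `CC(C)N(Cc1cccc(OCCCCCC(=O)O)c1)C(=O)c1ccc(-c2cccc(OCc3ccccc3)c2)cc1`, carries benzyloxy in place of phenyl on an aromatic carbon. In this assay compound 3 gives > 26000 nM, also a limit. The step that the two limits leave unreadable from compound 1 to compound 2 and the step that the two limits leave unreadable from compound 1 to compound 3 are thus of unreadable size, because of the limit of > 26000 nM in this assay, at which 3 of the 3 values shown sit. Compound 4, `Cc1nnc(-c2cccc(-c3ccc(C(=O)N(Cc4cccc(OCCCCCC(=O)O)c4)C(C)C)cc3)c2)o1`, has not yet been measured. Its difference from compound 1 is 5-methyl-1,3,4-oxadiazol-2-yl in place of phenyl on an aromatic carbon. The two measured steps bear on it only in that neither exchange of the outer aryl group brought a readable change in this assay, and no pattern beyond that can be drawn. The author therefore expects no step beyond the scatter, which a step that the limit leaves unreadable from compound 1 to compound 4 expresses, and estimates that compound 4 will give about 40000 nM in this assay, within 15000 nM to 150000 nM, most likely as a further limit.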

Compound 4, half-maximal effective concentration: > 26000 nM
Compound 4 gave a limit, no number (the forecaster's own chance of this, stated with the estimate: 85%); the middle value does not contradict the limit.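

The steps from compound 4 to compound 1, compound 2 and compound 3 cannot be read, because all four compounds end at the same limit: the limit of > 26000 nM in this assay, at which 4 of the 4 values shown sit.

The compounds shown leave open whether exchanging the outer group changes the result in this assay at all, and by how much, as none of them yields a number.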